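The source may report more compounds than this note shows. Statements on the series, on what has been measured and on what is new or still open speak of the compounds shown alone.

Measured compounds:
- compound 1 `CN(C)CCn1cnnc1-c1cc(Oc2ccc(NC(=O)Nc3cccc(C(F)(F)F)c3)cc2F)ccn1` in a functional assay on HT-29 cells (Homo sapiens) for antiproliferative activity, read by MTT assay, with a stated time of 72 h; a lower number here means a stronger inhibitor, a higher number a weaker inhibitor: 1470 nM
- compound 2 `CN(C)CCn1cnnc1-c1cc(Oc2ccc(NC(=O)Nc3ccccc3C(F)(F)F)cc2F)ccn1` in this assay: 5860 nM
- compound 3 `CN(C)CCn1cnnc1-c1cc(Oc2ccc(NC(=O)Nc3ccc(F)c(Cl)c3)cc2F)ccn1` in this assay: 720 nM

All three share one core and differ only in the ring attached to the urea nitrogen. Compound 2 gives the highest number of the three: the step of a 4.0-fold higher number from compound 1 to compound 2 (0.60 log units; beyond the scatter) lies beyond the scatter, as does an 8.1-fold lower number from compound 2 to compound 3 (0.91 log units; beyond the scatter), and a 2.0-fold lower number from compound 1 to compound 3 (0.31 log units; beyond the scatter) lies beyond it as well. Compound 4 `CCN(CC)CCn1cnnc1-c1cc(Oc2ccc(NC(=O)Nc3ccccc3C(F)(F)F)cc2F)ccn1` keeps the urea of compound 2 unchanged and alters the other end of the molecule: diethylamino in place of dimethylamino on a saturated chain carbon, two bonds along the chain from an aromatic nitrogen. None of the three measured steps touches this chain; each of them swaps the ring on the urea nitrogen and leaves the dimethylamino group in place. Going by the values given here, there is therefore no measured step from which the size of this change can be read, and the only guidance is that compound 2 itself sits at the weak end of the series. With nothing to show a shift in either direction, the expected step of a 1.1-fold lower number from compound 2 to compound 4 (0.03 log units; within the scatter) is one that stays within the scatter. Compound 4 is accordingly estimated at 5500 nM, with a range from 2000 nM to 15000 nM.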

Compound 4, half-maximal inhibitory concentration: 3410 nM
Estimate against measurement, compound 4: 1.6-fold (0.21 log units) above, within the range that was stated.
By their numbers in this assay, from the lowest: compound 3; then compound 1; then compounds 4 and 2 (each within the scatter of the next).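

In this assay, the exchange of dimethylamino for diethylamino on the saturated chain gives a 1.7-fold lower number from compound 2 to compound 4 (0.24 log units; within the scatter) and so does not separate the two compounds. Going by these compounds alone, this is the first reading from the amine end of the molecule: the earlier steps all changed the ring on the urea nitrogen and all lay beyond the scatter, whereas this change, with the 2-(trifluoromethyl)phenyl urea held fixed, leaves the number within it. Nothing measured here offers an explanation for this result.

Going by these compounds, the comparison rests on a single pair, so it remains open whether diethylamino would be tolerated in the same way alongside the 3-(trifluoromethyl)phenyl urea of compound 1 or the 3-chloro-4-fluorophenyl urea of compound 3, both of which give lower numbers than compound 2. On these data alone, it is also open whether a larger change at this end of the molecule, such as a primary amine or a carboxylic acid in place of the tertiary amine, or a longer chain leading to it, would move the number beyond the scatter.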